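The source may hold more compounds than are shown below. What is called first, only, known or untested is meant among the compounds shown, and "the series" means these compounds.

Compound 1 `CC[C@@H]1O[C@H](COCc2ccccc2)[C@@H](OCc2ccccc2)[C@H](OCc2ccccc2)[C@H]1O`: 19800 nM
Compound 2 `CC[C@H]1O[C@H](COCc2ccccc2)[C@@H](OCc2ccccc2)[C@H](OCc2ccccc2)[C@H]1O`: > 50000 nM

Of the compounds shown here, two have been measured in a functional assay on HeLa cells (Homo sapiens) for antiproliferative activity, read by sulforhodamine B assay; on this read-out higher numbers stand for weaker inhibition of growth and lower numbers for stronger inhibition of growth. Among the compounds with values here, compound 1 gives 19800 nM, the only actual number reported so far, so it is the sole anchor for any expectation. For compound 2 the read-out is a limit of the assay, > 50000 nM, and not a number. Within the data shown here, the one measured step, an at least 2.5-fold higher number from compound 1 to compound 2 (0.40 log units; beyond the scatter), rests on (the fact that compounds 1 and 2 differ only in the configuration as drawn), and its size is bounded by the limit of > 50000 nM in this assay, at which 1 of the 2 values shown sits. Compound 3 `CC(C)C[C@@H]1O[C@H](COCc2ccccc2)[C@@H](OCc2ccccc2)[C@H](OCc2ccccc2)[C@H]1O` differs from compound 1 in a different way: isopropyl in place of methyl on a saturated chain carbon bound to a saturated ring carbon. The measured step concerns configuration alone and says nothing about replacing ethyl with isobutyl at this carbon, so no measured comparison bears directly on the step from compound 1 to compound 3. In this assay compound 3 is expected to show a step of a 1.3-fold lower number from compound 1 to compound 3 (0.12 log units; within the scatter), which is not expected to reach beyond the scatter. The estimate for compound 3 is 15000 nM, expected to lie between 5000 nM and 45000 nM.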

Compound 3, concentration for 50% growth inhibition: > 50000 nM
Compound 3 gave a limit, no number; the forecaster's own chance of this, stated with the estimate: 15%; middle value at least 3.3-fold (0.52 log units) away from the limit.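

In this assay, the earlier pair had shown only that the configuration at a saturated ring carbon matters; this result shows that the chain carried on that carbon matters too, since isopropyl in place of methyl on a saturated chain carbon bound to a saturated ring carbon gives an at least 2.5-fold higher number from compound 1 to compound 3 (0.40 log units; beyond the scatter). Compound 3 reads > 50000 nM, which is a limit of the assay and not a number. The change from ethyl to isobutyl therefore weakens the inhibition of growth beyond the scatter, but only a lower bound on its size can be stated: the limit of > 50000 nM in this assay, at which 2 of the 3 values shown sit.

The compounds shown leave open whether any other group at this place would hold or improve on the activity of compound 1, for example a straight propyl chain, a shorter methyl or an amine-bearing chain. Within the data shown here, they also leave open whether the change from ethyl to isobutyl would have a comparable effect in the other configuration at the ring carbon, the one drawn in compound 2.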